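Methylsulfanyl for Iodo at a Second Ring Position

A few compounds are considered here, and "the series" means these few. Any claim that something is new, unique, unknown or untested is made for them only; others in the source may bear on it.

Compound 1 `O=C(CCCCCc1cccc(I)c1)N1CCOC1=O` and compound 2 `CSc1cccc(CCCCCC(=O)N2CCOC2=O)c1` share one core and differ by methylsulfanyl in place of iodo on an aromatic carbon. In an assay on HEK293 cells for inhibition of N-acylethanolamine-hydrolyzing acid amidase (Rattus norvegicus), read by LC-MS, with a stated time of 30 min (a lower number here means a stronger inhibitor, a higher number a weaker inhibitor), compound 1 gives 3120 nM. In this assay compound 2 gives 12800 nM. That exchange produced a 4.1-fold higher number from compound 1 to compound 2 (0.61 log units; beyond the scatter). Compound 3 `O=C(CCCCCc1ccc(I)cc1)N1CCOC1=O` is built from the same atoms as compound 1, joined differently; the difference between the two cores is not broken down here. In this assay compound 3 shows only > 20000 nM, which is a limit of the measurement and not a number. Compound 4 `CSc1ccc(CCCCCC(=O)N2CCOC2=O)cc1` differs from compound 3 by methylsulfanyl in place of iodo on an aromatic carbon, the same kind of change as before, now placed para to a large group rather than meta to a large group. For compound 4 the expected step is a step that the limit leaves unreadable from compound 3 to compound 4. This rests on the weakening seen in a 4.1-fold higher number from compound 1 to compound 2 (0.61 log units; beyond the scatter), while compound 3 already sits at the limit of > 20000 nM in this assay, at which 1 of the 3 values shown sits. For compound 4 the estimate is 50000 nM, between 15000 nM and 200000 nM.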

Compound 4, half-maximal inhibitory concentration: > 20000 nM
Compound 4: only a limit was reported; the forecaster's own chance of this, stated with the estimate: 85%; the middle value is on the limit's open side.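

Compound 3 and compound 4 both stop at a limit of the measurement in this assay, and the step between them cannot be read. The compounds shown leave open whether methylsulfanyl in place of iodo changes inhibition para to a large group as it does meta to a large group.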